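Adding a third methyl to compound 1

This account rests on a few compounds, and the source may have more. Where it says the series, first, only, none or still open, it means among the compounds named here.

- compound 1 `Cc1cccc(C)c1Oc1ccc([N+](=O)[O-])c(Nc2ccc(C#N)cc2)c1`: 69600 nM
- compound 2 `Cc1cc(C)c(Oc2cc(Nc3ccc(C#N)cc3)c(N)cc2[N+](=O)[O-])c(C)c1`: 32200 nM
- compound 3 `Cc1cccc(C)c1Oc1cc(Nc2ccc(C#N)cc2)c([N+](=O)[O-])cc1[N+](=O)[O-]`: > 61800 nM (a limit of the assay)

In an ADME assay on H9 cells (Homo sapiens) for cytotoxicity, read by XTT assay, with a stated time of 6 days (a lower number here means that less compound is tolerated, a higher number that more compound is tolerated), compound 1 gives 69600 nM, the higher of the two exact numbers. Compound 2 gives 32200 nM, lower by a gap beyond the scatter. Compound 3 shows only a limit of the assay, > 61800 nM.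

Compound 4 `Cc1cc(C)c(Oc2ccc([N+](=O)[O-])c(Nc3ccc(C#N)cc3)c2)c(C)c1` differs from compound 1 by one change: methyl in place of hydrogen on an aromatic carbon. This turns 2,6-dimethylphenyl into 2,4,6-trimethylphenyl.

Little of the measured evidence bears on this change. Going by the values given here, the only measured single-place step, a step that the limit leaves unreadable from compound 1 to compound 3, is a different change and has no readable size. With a core unlike that of compound 1, compound 2 carries the same 2,4,6-trimethylphenyl group and gives 32200 nM, which hints at a slight lean downward.

In this assay the expected step, a 1.4-fold lower number from compound 1 to compound 4 (0.14 log units; within the scatter), is therefore not expected to pass the scatter. Compound 4 is estimated at 50000 nM, with an expected range of 22000 nM to 100000 nM.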

Compound 4, half-maximal cytotoxic concentration: > 67000 nM
Compound 4: no number, only a limit; the forecaster's own chance of this, stated with the estimate: 30%; middle value at least 1.3-fold (0.12 log units) from the limit.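

In this assay compound 4 gives only a limit of the assay, > 67000 nM, so the step from compound 1 to compound 4 cannot be read. The compounds shown leave open whether the added methyl changes how much compound the cells tolerate.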